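A hexyl chain in place of an aryl ring

This account rests on a few compounds, and the source may have more. Where it says the series, first, only, none or still open, it means among the compounds named here.

Compound 2 `Cc1cccc(C(=O)NN(C(=O)c2ccccc2Cl)C(C)(C)C)c1` was tested in an assay on cells for agonist activity at ecdysone receptor (Bombyx mori), read by a luciferase reporter, with a stated time of 24 h (a lower number here means that less compound is needed, a higher number that more compound is needed for the effect), and gave 603 nM. Compound 1 `CCc1ccccc1C(=O)N(NC(=O)c1ccccc1)C(C)(C)C` gives 589 nM in the same test, so the two values stand within the scatter of each other. Compound 3 `CCCCCCC(=O)NN(C(=O)c1ccccc1Cl)C(C)(C)C` has not yet been measured; it differs from compound 2 in one place: hexyl in place of 3-methylphenyl on a carbonyl carbon. No measured step of this kind is shown, so the expectation rests on this change alone. The expected step from an 8.3-fold higher number from compound 2 to compound 3 (0.92 log units; beyond the scatter) is toward a higher number, well beyond the scatter. Compound 3 is estimated at 5000 nM, within a range from 1000 nM to 30000 nM.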

Compound 3, half-maximal effective concentration: 741 nM
For compound 3 the middle estimate is 6.7-fold (0.83 log units) above the measured one; measured number outside the range, below it.
By their numbers in this assay, from the lowest: compounds 1, 2 and 3 (each within the scatter of the next).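

In this assay, the step from the 3-methylphenyl ring to the open hexyl chain on this carbonyl carbon is a 1.2-fold higher number from compound 2 to compound 3 (0.09 log units; within the scatter). For compound 2 and compound 3, then, an aromatic ring at this place is not needed to keep the reading within the scatter. No measurement shown bears on why the ring and the chain read alike. Going by these compounds, whether a shorter chain, a longer chain or a chain ending in an amine or a carboxylic acid would read the same here remains open. So does whether this exchange would hold on any other core.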